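The source may hold more compounds than are shown below. What is called first, only, known or untested is meant among the compounds shown, and "the series" means these compounds.

Compound 1: `C/C(=C\C(=O)Nc1ccccc1OCCCC(=O)O)c1ccc2c(ccn2Cc2ccc(C(F)(F)F)cc2)c1` gives 300 nM in an assay on Prostate gland for inhibition of steroid 5-alpha-reductase (Rattus norvegicus); on this read-out lower numbers stand for stronger inhibition and higher numbers for weaker inhibition.
Compound 2: `C/C(=C\C(=O)Nc1ccccc1OCCCC(=O)O)c1ccc2c(ccn2C(c2ccccc2)C(C)C)c1` gives 25 nM in this assay.

Among the compounds with values here, of the two measured compounds, compound 2 stands at the lower number in this assay; the only comparison it has is a 12-fold lower number from compound 1 to compound 2 (1.08 log units; beyond the scatter). Compound 3 is `C/C(=C\C(=O)Nc1ccccc1OCCCC(=O)O)c1ccc2c(ccn2C(c2ccccc2)c2ccc(C(F)(F)F)cc2)c1`, not yet measured; it differs from compound 2 by 4-(trifluoromethyl)phenyl in place of isopropyl on a saturated chain carbon bound to an aromatic carbon and an aromatic nitrogen. Within the data shown here, the one measured step, a 12-fold lower number from compound 1 to compound 2 (1.08 log units; beyond the scatter), bears on it only indirectly: it shows that the shared core tolerates a branched group on the aromatic nitrogen well, but no step shows what happens when isopropyl is exchanged for a second aromatic ring on that branching carbon. Because compound 2 reached 25 nM with the phenyl branch kept in compound 3, the expectation is for a number near that of compound 2, with a small step, a 1.6-fold higher number from compound 2 to compound 3 (0.20 log units; within the scatter), that may not exceed the scatter. Compound 3 is therefore estimated at 40 nM, within a range from 10 nM to 160 nM.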

Compound 3, half-maximal inhibitory concentration: 8.1 nM
Estimate against measurement, compound 3: 4.9-fold (0.69 log units) above; the measured number lies below the stated range.
By their numbers in this assay, from the lowest: compound 3; then compound 2; then compound 1.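

In this assay, a 4-(trifluoromethyl)phenyl group in place of isopropyl on the saturated chain carbon bound to an aromatic carbon and an aromatic nitrogen gives a 3.1-fold lower number from compound 2 to compound 3 (0.49 log units; beyond the scatter) and so a real difference, showing that this branching carbon accepts a second aromatic ring and not only a small alkyl branch. Phenyl in place of hydrogen on that same carbon gives a 37-fold lower number from compound 1 to compound 3 (1.57 log units; beyond the scatter) and is the largest step among these compounds, so branching with a ring here counts for far more than the exchange of one branch for the other. Nothing at hand explains why these changes lower the number.

As far as these compounds go, it remains open whether the trifluoromethyl group itself contributes to the lower number or whether the aromatic ring alone suffices. A second unsubstituted phenyl, a cyclohexyl ring or a methoxy group on that ring would separate these two possibilities.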